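The source may hold more compounds than are shown below. What is called first, only, known or untested is meant among the compounds shown, and "the series" means these compounds.

Working notes on a small series measured in a functional assay on BT-549 cells (Homo sapiens) for cytotoxicity, read by sulforhodamine B assay, with a stated time of 48 h; a lower number here means that less compound is tolerated, a higher number that more compound is tolerated. Compound 1 `Nc1nc(Cl)c2ncn(Cc3ccccc3CCl)c2n1` gives 57500 nM in this assay, the highest of the two numbers in hand; compound 2 `ClCc1ccccc1Cn1cnc2nc(Cl)nc(Cl)c21` gives 7070 nM, the nearest value, and the gap between the two lies beyond the scatter. Compound 3 `ClCc1ccccc1Cn1cnc2c(Cl)nc(Cl)nc21` is not yet measured; it differs from compound 1 by chloro in place of amino on an aromatic carbon. For compound 3 a lower number than compound 1 is expected in this assay, because compound 2, which also carries two chloro groups, gives 7070 nM there. The estimate for compound 3 is 9000 nM, range 3000 nM to 30000 nM, a step of a 6.4-fold lower number from compound 1 to compound 3 (0.81 log units; beyond the scatter) expected beyond the scatter.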

Compound 3, concentration lethal to 50% of the cells: 4160 nM
The estimate for compound 3 lay 2.2-fold (0.34 log units) above the measured number, within the range that was stated.
By their numbers in this assay, from the lowest: compounds 3 and 2 (each within the scatter of the next); then compound 1.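

Chloro in place of amino on the aromatic carbon between two ring nitrogen atoms gives a 14-fold lower number from compound 1 to compound 3 (1.14 log units; beyond the scatter) in this assay and is the first single-place step in the series. It shows that the read-out responds to the group at this position, with less compound tolerated when chloro stands there than when amino does. Nothing in hand accounts for the size of this step.

From the compounds shown here alone, it remains open whether fluoro, methoxy or a dimethylamino group at this position would track chloro or amino. The compounds shown also leave open whether a change to the chloromethyl group would alter the number.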